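Moving the Hydroxyl Around a Phenyl Ring

This account rests on a few compounds, and the source may have more. Where it says the series, first, only, none or still open, it means among the compounds named here.

Compound 1 `Oc1cccc(-c2cc(-c3ccc(Cl)cc3)nc(-c3ccccn3)c2)c1` was tested in an ADME assay on HEK293 cells (Homo sapiens) for cytotoxicity, read by CCK-8 assay and cell counting, with a stated time of 2 days (on this read-out lower numbers stand for stronger inhibition and higher numbers for weaker inhibition), and gave 14000 nM. Compound 2 `Oc1ccc(-c2cc(-c3ccncc3)nc(-c3ccc(Cl)cc3)c2)cc1` stands without a number in this assay, its result being recorded as "not determined" (no result reported). Compound 3 `Oc1cccc(-c2cc(-c3ccncc3)nc(-c3ccc(Cl)cc3)c2)c1` differs from compound 2 by 3-hydroxyphenyl in place of 4-hydroxyphenyl on an aromatic carbon. Among the compounds with values here, no step between measured compounds is available, so the size of this change cannot be read from the data. Since compound 1 also carries a 3-hydroxyphenyl group and gave 14000 nM, a shift in this assay no larger than the scatter, in either direction, is expected. Compound 3 is therefore expected to give about 14000 nM, within 5000 nM to 40000 nM.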

Compound 3, half-maximal inhibitory concentration: 2890 nM
Beside the measured number, compound 3's estimate is 4.8-fold (0.69 log units) above it, and the stated range ends above it.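

Read in this assay the change of pyridin-2-yl to pyridin-4-yl, with the 3-hydroxyphenyl group kept, gives a 4.8-fold lower number from compound 1 to compound 3 (0.69 log units; beyond the scatter) and so shows that the place of the pyridine nitrogen alters the number beyond the scatter. The step from 4-hydroxyphenyl to 3-hydroxyphenyl cannot be read: compound 2 has no number. No evidence is at hand that bears on this result. Going by these compounds, it remains open how a pyridin-3-yl group would compare, and whether an amine or a carboxylic acid in place of the hydroxyl would shift the number.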